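The compounds below may be only part of what the source reports. "The series", "measured", "known", "first", "only" and "open" are said of these compounds alone.

Compound 2 `CCCCNc1nc(N)nc2c1CN(Cc1ccncc1)CC2` is the starting point. For the measured compounds named here, in an assay on HEK293 cells for agonist activity at Toll-like receptor 8 (Homo sapiens), read by a luciferase reporter, with a stated time of 6 h (on this read-out higher numbers stand for an effect only at larger amounts of compound and lower numbers for an effect already at smaller amounts), compound 2 gives 0.29 uM, the higher of the two numbers measured so far. Going by the values given here, its close relative compound 1 `CCCCNc1nc(N)nc2c1CN(Cc1ccc(OC)cc1)CC2` gives 0.08 uM in this assay, and the single measured step between the two, a 3.6-fold higher number from compound 1 to compound 2 (0.56 log units; beyond the scatter), comes from swapping the group on the same ring amine nitrogen that is altered again here. Compound 3 `CCCCNc1nc(N)nc2c1CN(C(=O)c1cnccn1)CC2` differs from compound 2 in one place: (pyrazin-2-yl)carbonyl in place of (pyridin-4-yl)methyl on an amine nitrogen in a ring. This exchange is larger than the measured one, since both the aromatic ring and the link joining it to the nitrogen are replaced, so the earlier step is only a loose guide. Among the compounds with values here, it shows that the group at this position can shift the number by a modest amount, but nothing measured so far shows which way a carbonyl in place of a saturated chain carbon would shift it. A step of uncertain direction, leaning slightly toward a higher number, is therefore expected, a 1.7-fold higher number from compound 2 to compound 3 (0.24 log units; within the scatter). For compound 3 the estimated value in this assay is 0.5 uM, with a range from 0.1 uM to 3 uM.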

Compound 3, minimum effective concentration: 2.2 uM
The estimate for compound 3 lay 4.4-fold (0.64 log units) below the measured number, and the stated range covers the measured number.
By their numbers in this assay, from the lowest: compound 1; then compound 2; then compound 3.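

In this assay, the exchange of (pyridin-4-yl)methyl for (pyrazin-2-yl)carbonyl gives a 7.6-fold higher number from compound 2 to compound 3 (0.88 log units; beyond the scatter) and is beyond the usual scatter, so this ring amine nitrogen tolerates a change of group less freely than the opening estimate allowed. For the compounds shown here, it is also the first measured step at this position that alters the link to the nitrogen, with a carbonyl taking the place of a saturated chain carbon. Together with a 3.6-fold higher number from compound 1 to compound 2 (0.56 log units; beyond the scatter) as the earlier step, it means that both measured changes at this nitrogen move toward a higher number, so more compound is needed for an effect, and compound 3 stands highest of the three.

Going by these compounds, the aromatic ring and the link changed together, so these compounds cannot separate their shares of the step, and the effect of (pyridin-4-yl)carbonyl or (pyrazin-2-yl)methyl on the same nitrogen, or of a small group such as acetyl, stays open. No measurement shown here gives a reason for the rise in the number.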